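This account rests on a few compounds, and the source may have more. Where it says the series, first, only, none or still open, it means among the compounds named here.

Measured so far:
Compound 2, `Cc1c(OCCCCOc2ccc(C(=O)O)cc2)ccc(C(=O)CC(C)C)c1O`: 66%
Compound 3, `Cc1c(OCCCCOc2ccc(F)c(C(=O)O)c2)ccc(C(=O)CC(C)(C)C)c1O`: 58%
Compound 1, `COc1cc(C(=O)O)ccc1OCCCCOc1ccc(C(=O)CC(C)(C)C)c(O)c1C`: 49%

In an ADME assay (liver) for metabolic stability, with Liver microsome (Rattus norvegicus) as the target, read by LC-MS, using microsomes and NADPH, with stated times of 5 min and 60 min, tested at 4 uM (on this read-out higher numbers stand for a more stable compound and lower numbers for a less stable compound), compound 2 gives 66%, the highest of the three numbers. Compound 3 gives 58%, which lies within the usual scatter of compound 2, so the two cannot be placed in any order. Compound 1 gives 49%, and its gap to compound 2 is beyond the scatter, so compound 2 is clearly more stable than compound 1.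

Compound 4, `Cc1ccc(C(=O)O)cc1OCCCCOc1ccc(C(=O)CC(C)C)c(O)c1C`, has not yet been measured. It differs from compound 2 in one place: 5-carboxy-2-methylphenyl in place of 4-carboxyphenyl on an oxygen on a saturated carbon

Within the data shown here, the three measured compounds differ from one another in more than one place, so no single step of this kind can be read from them. The expectation for compound 4 therefore rests on compound 2 alone, with the unrelated changes seen in compound 1 and compound 3 giving only a loose sense of how much such a ring change can move the number. The expected step of a number 10 percentage points lower from compound 2 to compound 4 (within the scatter) is a small one downward, around the edge of the scatter rather than clearly beyond it. Compound 4 is thus expected to give about 56%, with a likely range from 36% to 74%.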

Compound 4, percent of the compound remaining: 21%
Estimate against measurement, compound 4: 35 percentage points above; the measured number lies below the stated range.
By their numbers in this assay, from the lowest: compound 4; then compounds 1, 3 and 2 (each within the scatter of the next, the first and the last beyond it).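

Swapping 4-carboxyphenyl for 5-carboxy-2-methylphenyl on the oxygen on a saturated carbon gives a number 45 percentage points lower from compound 2 to compound 4 (beyond the scatter) in this assay, and this is the first step here that can be read on its own, as the earlier compounds differ from one another in more than one place. The two groups have the same kind of ring, the same counts of hydrogen-bond donors and acceptors and no net charge, and the entering group is larger by a single heavy atom, so a change that looks small on paper can move this number far beyond the scatter at this position. Nothing measured here bears on why the number falls so far.

The names of the two groups show two differences within this one change, an added methyl and a carboxy group at a different ring number, and the compounds shown do not tell which of them matters or whether both are needed. They also leave open how this position would respond to other groups, such as a chlorine atom on the ring or an amide in place of the carboxylic acid.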